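The source may hold more compounds than are shown below. What is called first, only, known or untested is meant among the compounds shown, and "the series" means these compounds.

Compound 1, `COc1cc(/C(Cl)=C/C=C(\C#N)C(=O)c2c[nH]c3ccccc23)cc(OC)c1OC`: 73.3%
Compound 2, `COc1ccc2[nH]cc(C(=O)/C(C#N)=C/C=C(\Cl)c3ccc(Br)cc3)c2c1`: 76.7%
Compound 3, `N#C/C(=C\C=C(/Cl)c1ccc(Br)cc1)C(=O)c1c[nH]c2ccccc12`: 76.7%

In a functional assay for inhibition, read by Griess assay, with a stated time of 150 min, tested at 1 mM (on this read-out higher numbers stand for more inhibition at the one concentration tested (going by the name of the read-out) and lower numbers for less inhibition), compound 2 gives 76.7%, level at the digits shown with compound 3, which gives 76.7%. Compound 1 gives 73.3%, a number that sits within the scatter of the other two, so the three measured compounds cannot be told apart on this read-out. Within the data shown here, the single measured one-place step, no change at the digits printed from compound 2 to compound 3 (within the scatter), removes a methoxy from an aromatic carbon of the shared core and leaves the number unchanged within the scatter.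

Compound 4, `COc1ccc(/C(Cl)=C/C=C(\C#N)C(=O)c2c[nH]c3ccc(OC)cc23)cc1`, differs from compound 2 in one place: methoxy in place of bromo on an aromatic carbon. Among the measured compounds shown here, no measured step exchanges a bromo for a methoxy, so the step from compound 2 to compound 3 bears on this change only indirectly, by showing that one methoxy elsewhere on the core made no difference beyond the scatter. For the measured compounds named here, with all three measured numbers close together and the only measured step flat, a step of no size beyond the scatter is expected, a number 2.7 percentage points lower from compound 2 to compound 4 (within the scatter). Compound 4 is therefore estimated at 74%, with a range from 60% to 86%.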

Compound 4, a percentage reported as inhibition, at one concentration (the size of the read-out at that concentration, not a potency): 41.6%
The estimate for compound 4 lay 32.4 percentage points above the measured number; the whole stated range lies above it.
By their numbers in this assay, from the lowest: compound 4; then compounds 1, 2 and 3 (each within the scatter of the next).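

In this assay, going from 4-bromophenyl to 4-methoxyphenyl gives a number 35.1 percentage points lower from compound 2 to compound 4 (beyond the scatter), so this place on the six-membered aromatic ring of carbon only, para to a large group, is one where the choice of group clearly moves the read-out. The earlier step, no change at the digits printed from compound 2 to compound 3 (within the scatter), changed a different place on the molecule, so its flat result said nothing about this one, and the two places now read differently. Nothing measured here explains why methoxy gives less inhibition than bromo in this pair.

Going by these compounds, this comparison rests on a single pair of compounds that differ only at this place, so it stays open whether the step belongs to methoxy in particular or would appear with other replacements for bromo. The compounds shown also do not tell whether an amine, a carboxylic acid or a plain hydrogen here would read close to compound 2 or close to compound 4, or whether the same swap would give a step of this size on a core without its methoxy.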